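A few compounds are considered here, and "the series" means these few. Any claim that something is new, unique, unknown or untested is made for them only; others in the source may bear on it.

In a functional assay on PC-3 cells (Homo sapiens) for cytotoxicity, read by MTT assay, with a stated time of 72 h (a higher number here means a weaker inhibitor, a lower number a stronger inhibitor), compound 1 (`O=C(N/N=C/c1cccc(Br)c1)Nc1cc2c(Nc3ccc(F)c(Cl)c3)ncnc2cc1O[C@H]1CCOC1`) gives 15500 nM and compound 2 (`COc1ccc(/C=N/NC(=O)Nc2cc3c(Nc4ccc(F)c(Cl)c4)ncnc3cc2O[C@H]2CCOC2)cc1`) gives 34100 nM, the higher of the two numbers. Compound 3 (`O=C(N/N=C/c1ccc(O)cc1O)Nc1cc2c(Nc3ccc(F)c(Cl)c3)ncnc2cc1O[C@H]1CCOC1`) differs from compound 2 by a single change: 2,4-dihydroxyphenyl in place of 4-methoxyphenyl on a carbon with a double bond to nitrogen. Within the data shown here, the only measured step at this place is a 2.2-fold higher number from compound 1 to compound 2 (0.34 log units; beyond the scatter), which is modest. Among the measured compounds shown here, no measured compound carries the 2,4-dihydroxyphenyl group, so the direction is weakly supported, but a modest move back toward the value of compound 1 is expected. The expected step is a 2.1-fold lower number from compound 2 to compound 3 (0.33 log units; beyond the scatter). For compound 3, the estimated value is 16000 nM, with an expected range of 5000 nM to 45000 nM.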

Compound 3, half-maximal inhibitory concentration: 7540 nM
For compound 3 the middle estimate is 2.1-fold (0.33 log units) above the measured one; the range from low to high includes it.
By their numbers in this assay, from the lowest: compound 3; then compound 1; then compound 2.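

In this assay, 2,4-dihydroxyphenyl in place of 4-methoxyphenyl on a carbon with a double bond to nitrogen gives a 4.5-fold lower number from compound 2 to compound 3 (0.66 log units; beyond the scatter). The same group in place of 3-bromophenyl gives a 2.1-fold lower number from compound 1 to compound 3 (0.31 log units; beyond the scatter), so compound 3 holds the lowest number of the three and the earlier single upward step now has downward counterparts at this position. No measurement at hand explains these steps. From the compounds shown here alone, it remains open whether both hydroxyl groups are needed for these steps, as 4-hydroxyphenyl would test. Going by these compounds, how an aminophenyl or carboxyphenyl group would compare also remains open.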